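The source may hold more compounds than are shown below. What is called first, only, known or untested is meant among the compounds shown, and "the series" means these compounds.

Measured so far:
compound 1 `COC(=O)c1cc(=O)c2cc(NC(=O)Nc3ccc(Cl)c(Cl)c3)ccc2[nH]1` — > 6350 nM
compound 2 `COC(=O)c1cc(=O)c2cc(NC(=O)Nc3ccc(F)c(Cl)c3)ccc2[nH]1` — > 6350 nM
compound 3 `COC(=O)c1cc(=O)c2cc(NC(=O)NCc3ccccc3)ccc2[nH]1` — > 19500 nM

In a functional assay on UoC-B1 cells (Homo sapiens) for antiproliferative activity, with a stated time of 72 h (a lower number here means that less compound is needed, a higher number that more compound is needed for the effect), compound 1 gives only a limit, > 6350 nM. Compound 2 likewise gives only a limit, > 6350 nM. Compound 3 gives only a limit as well, > 19500 nM. All three values therefore sit at limits, one at the limit of > 19500 nM in this assay, at which 1 of the 3 values shown sits, and two at the limit of > 6350 nM in this assay, at which 2 of the 3 values shown sit, so compound 3 stands at the higher of the two limits and cannot be placed against compounds 1 and 2.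

The next compound is compound 4 `COC(=O)c1cc(=O)c2cc(NC(=O)Nc3ccc4c(c3)CCC4)ccc2[nH]1`. The change is 2,3-dihydro-1H-inden-5-yl in place of benzyl on an amide-type nitrogen. The measured steps that bear on it are a step that the two limits leave unreadable from compound 1 to compound 3, a step that the two limits leave unreadable from compound 2 to compound 3 and a step that the two limits leave unreadable from compound 1 to compound 2, none of which is readable in size, since every compound reaches only a limit. No step beyond the scatter can thus be expected in this assay; compound 4 is expected to remain near the limits. The estimated step is an at least 1.3-fold lower number from compound 3 to compound 4 (0.11 log units; that floor lies within the scatter). Compound 4 is estimated at 15000 nM, with a range from 4000 nM to 60000 nM.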

Compound 4, half-maximal effective concentration: > 24100 nM
Compound 4: only a limit was reported (the forecaster's own chance of this, stated with the estimate: 70%); middle value at least 1.6-fold (0.20 log units) from the limit.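

In this assay compound 4 gives only a limit, > 24100 nM. For the compounds shown here, no step from compound 1, compound 2 or compound 3 to compound 4 can be read. The compounds shown leave open which group on the amide-type nitrogen, if any, gives a measurable value in this assay.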